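A Fluoro Substituent Added to Compound 3

The source may hold more compounds than are shown below. What is called first, only, known or untested is meant among the compounds shown, and "the series" means these compounds.

The series is followed in a functional assay on CCRF-CEM cells (Homo sapiens) for inhibition; on this read-out higher numbers stand for weaker inhibition and lower numbers for stronger inhibition. Compound 1, `O=C1/C(=C/c2ccc(Cl)cc2)Cc2ccccc21`, gives 284000 nM in this assay. Compound 2, `COc1cccc(/C=C2\Cc3ccccc3C2=O)c1`, reaches only a limit of the assay, > 500000 nM, and no number is known for it; one of the three results shown sits at this limit (the limit of > 500000 nM in this assay, at which 1 of the 3 values shown sits). Compound 3, `O=C1/C(=C/c2ccccc2)CCc2ccccc21`, gives 7420 nM in this assay, the lowest of the two numbers that were obtained, and the gap to compound 1 lies beyond the usual scatter of such measurements.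

Compound 4, `O=C1/C(=C/c2cccc(F)c2)CCc2ccccc21`, has not yet been measured in this assay. It differs from compound 3 in one place: fluoro in place of hydrogen on an aromatic carbon. The fluoro enters on an aromatic carbon of a six-membered aromatic ring of carbon only, meta to a large group. Going by the values given here, no pair of measured compounds in this set shows such a change, so the size of the step cannot be read from the data. A change of this kind is expected to move the number little, and the step of a 1.2-fold lower number from compound 3 to compound 4 (0.09 log units; within the scatter) is estimated to lie within the scatter. Compound 4 is therefore expected to give about 6000 nM in this assay, within a range from 2500 nM to 15000 nM.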

Compound 4, half-maximal inhibitory concentration: 8010 nM
For compound 4 the middle estimate is 1.3-fold (0.13 log units) below the measured one, within the range that was stated.
By their numbers in this assay, from the lowest: compounds 3 and 4 (each within the scatter of the next); then compound 1. At a limit, above all of these: compound 2.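

In this assay, fluoro in place of hydrogen on an aromatic carbon, meta to a large group, gives a 1.1-fold higher number from compound 3 to compound 4 (0.03 log units; within the scatter). Going by these compounds alone, this is the first pair that differs in one place only, so it gives the first direct reading of a single change: at this position, a fluoro leaves the read-out within the scatter of the hydrogen parent, and this carbon of the six-membered aromatic ring can carry this one heavy atom with no measurable change in inhibition. The data shown offer no evidence that bears on why this step is so small.

Going by these compounds, it remains open whether a different group on the same carbon, such as an amine, a carboxylic acid or a trifluoromethyl, would also stay within the scatter of compound 3, or whether it would move the number clearly in either direction. On these data alone, it is equally open whether fluoro on another carbon of that ring would behave in the same way, and whether the same change would stay as small on the core of compound 1.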